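From quinolin-5-yl to 6-fluoropyridin-3-yl on a shared core

A few compounds are considered here, and "the series" means these few. Any claim that something is new, unique, unknown or untested is made for them only; others in the source may bear on it.

Measured in a functional assay on MDA-MB-436 cells (Homo sapiens) for antiproliferative activity, read by MTT assay, with a stated time of 48 h; on this read-out higher numbers stand for weaker inhibition and lower numbers for stronger inhibition:
- compound 1 `C=CS(=O)(=O)N1CCN(c2ncnc3sc(-c4ccc(OC)cc4)cc23)CC1`: 28400 nM
- compound 2 `C=CS(=O)(=O)N1CCN(c2ncnc3sc(-c4cccc5ncccc45)cc23)CC1`: 25900 nM
- compound 3 `C=CS(=O)(=O)N1CCN(c2ncnc3sc(-c4cn(S(=O)(=O)c5ccccc5)c5ccccc45)cc23)CC1`: 38000 nM

In this assay compound 2, at 25900 nM, cannot be separated from compound 1 or compound 3, since both gaps lie within the scatter. Compound 4 `C=CS(=O)(=O)N1CCN(c2ncnc3sc(-c4ccc(F)nc4)cc23)CC1` carries a single change relative to compound 2: 6-fluoropyridin-3-yl in place of quinolin-5-yl on an aromatic carbon. The group is exchanged on an aromatic carbon next to the ring sulfur.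

Among the compounds with values here, only one measured step bears directly on this change, and it concerns the same carbon: a 1.1-fold lower number from compound 1 to compound 2 (0.04 log units; within the scatter). Compound 3, which carries a different group at that carbon, gives 38000 nM, so its value also stays in the same range. Across these three compounds, then, changing this group has not moved the value beyond the scatter. However, none of them shows how a fluoropyridine behaves. No shift beyond the scatter, in either direction, is therefore expected, and the expected step is a 1.1-fold higher number from compound 2 to compound 4 (0.03 log units; within the scatter). For compound 4 the estimated value is 28000 nM, with an expected range from 14000 nM to 55000 nM.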

Compound 4, half-maximal inhibitory concentration: 17500 nM
Compound 4: the middle estimate sits 1.6-fold (0.20 log units) above what was measured, within the range that was stated.
By their numbers in this assay, from the lowest: compounds 4, 2, 1 and 3 (each within the scatter of the next, the first and the last beyond it).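

In this assay, exchanging quinolin-5-yl for 6-fluoropyridin-3-yl on the aromatic carbon next to the ring sulfur gives a 1.5-fold lower number from compound 2 to compound 4 (0.17 log units; within the scatter), and exchanging 4-methoxyphenyl for the same group gives a 1.6-fold lower number from compound 1 to compound 4 (0.21 log units; within the scatter), so a single aromatic ring carrying fluorine is tolerated here as well as the groups seen earlier. Within the data shown here, compound 4 at 17500 nM and compound 3 at 38000 nM are nevertheless the first pair whose values lie beyond the scatter of each other, which shows that the group at this carbon can separate compounds, though only modestly. No measurement shown offers an explanation for this difference.

Going by these compounds, how pyridin-3-yl without the fluorine would compare with compound 4 remains open. So does whether an amine or a morpholine on this carbon would give a value outside this range.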